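Hydroxy for methyl on a second ketone core

A few compounds are considered here, and "the series" means these few. Any claim that something is new, unique, unknown or untested is made for them only; others in the source may bear on it.

Measured so far:
compound 1 `Cc1c(OCCCCOc2ccc(C(=O)O)cc2)ccc(C(=O)CC2CCCC2)c1O`: 26.7%
compound 2 `Cc1c(OCCCCOc2ccc(C(=O)O)cc2)ccc(C(=O)CC2CCCC2)c1C`: 12.2%
compound 3 `Cc1c(OCCCCOc2ccc(C(=O)O)cc2)ccc(C(=O)CC(C)C)c1C`: 16.6%

Of the compounds shown here, three have been read in an assay on HEK293 cells for positive allosteric modulation of metabotropic glutamate receptor 3 (Rattus norvegicus), read by thallium flux, with a stated time of 2.5 min; a lower number here means a smaller maximal response, a higher number a larger maximal response. Compound 2 and compound 1 differ by hydroxy in place of methyl on an aromatic carbon; this change made a step of a number 14.5 percentage points higher from compound 2 to compound 1 (beyond the scatter). Compound 2 and compound 3 differ in their cores by isopropyl in place of cyclopentyl on a saturated chain carbon bound to a carbonyl carbon, and this step, a number 4.4 percentage points higher from compound 2 to compound 3 (within the scatter), stays within the scatter.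

Compound 4 `Cc1c(OCCCCOc2ccc(C(=O)O)cc2)ccc(C(=O)CC(C)C)c1O` is not yet measured. It differs from compound 3 by hydroxy in place of methyl on an aromatic carbon. This is the same kind of change as from compound 2 to compound 1, though not the same: around the place it sits ortho to an isobutylcarbonyl group in compound 4, where in compound 1 it sits ortho to a (cyclopentylmethyl)carbonyl group; in both it is ortho to a methyl group and meta to a large group.

Since the core difference, a number 4.4 percentage points higher from compound 2 to compound 3 (within the scatter), lies within the scatter, the measured step, a number 14.5 percentage points higher from compound 2 to compound 1 (beyond the scatter), is expected to repeat on the other core, so a step of about a number 12.4 percentage points higher from compound 3 to compound 4 (beyond the scatter) is expected in this assay. Compound 4 is therefore estimated at 29%, expected between 18% and 42%; this rests on one pair only.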

Compound 4, largest response reached (reported as percent of maximum), in percent of the reference or control that the assay uses: 51.9%
The estimate for compound 4 lay 22.9 percentage points below the measured number, outside the stated range (above it).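

In this assay, hydroxy in place of methyl on an aromatic carbon gave a number 35.3 percentage points higher from compound 3 to compound 4 (beyond the scatter), so the direction held on the core of compound 3, but the size of the step did not carry over: the same change on two cores in this assay, a number 14.5 percentage points higher (beyond the scatter) from compound 2 to compound 1 and a number 35.3 percentage points higher (beyond the scatter) from compound 3 to compound 4, 20.8 percentage points apart, beyond the scatter of two such steps

Seen from the other place, isopropyl in place of cyclopentyl gave a number 25.2 percentage points higher from compound 1 to compound 4 (beyond the scatter), a different result with hydroxy present than with methyl present: the same change on two cores in this assay, a number 4.4 percentage points higher (within the scatter) from compound 2 to compound 3 and a number 25.2 percentage points higher (beyond the scatter) from compound 1 to compound 4, 20.8 percentage points apart, beyond the scatter of two such steps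

In these four compounds the two changes therefore do not act independently, and a step measured on one core is a poor guide to its size on the other; this does not show why they combine in this way, and two pairs give no rule for a third core.

The compounds shown leave open whether a methoxy or an amino group on that aromatic carbon would behave as hydroxy does. They also leave open how a cyclohexyl group or a longer chain in place of isopropyl would fare with hydroxy present.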